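The source may hold more compounds than are shown below. What is called first, only, known or untested is meant among the compounds shown, and "the series" means these compounds.

Compound 1 `Cc1ccc(/C=C2\CN(Cc3cn(Cc4ccccc4F)nn3)C/C(=C\c3ccc(C)cc3)C2=O)cc1` is the only one of the three measured compounds to give a number in a functional assay on MCF7 cells (Homo sapiens) for cytotoxicity, read by MTT assay, with a stated time of 24 h; a higher number here means a weaker inhibitor, a lower number a stronger inhibitor: compound 1 gives 28700 nM. Compound 2 `COc1ccc(/C=C2\CN(Cc3cn(Cc4ccccc4Cl)nn3)C/C(=C\c3ccc(OC)cc3)C2=O)cc1` reaches only a limit of the assay in this assay, at > 100000 nM. Compound 3 `COc1ccc(/C=C2\CN(Cc3cn(Cc4ccccc4F)nn3)C/C(=C\c3ccc(OC)cc3)C2=O)cc1` likewise reaches only a limit of the assay in this assay, at >= 100000 nM. How the core of compound 1 differs from the core of compound 3 is not broken down here. The change from compound 3 to compound 2 is chloro in place of fluoro on an aromatic carbon, and it gives a step that the two limits leave unreadable from compound 3 to compound 2. The same change made on compound 1 gives compound 4 `Cc1ccc(/C=C2\CN(Cc3cn(Cc4ccccc4Cl)nn3)C/C(=C\c3ccc(C)cc3)C2=O)cc1`, namely (chloro in place of fluoro on an aromatic carbon). The measured step has no readable size, and the expectation therefore rests on compound 1 and its 28700 nM. Compound 4 is expected to show a step of a 1.1-fold higher number from compound 1 to compound 4 (0.05 log units; within the scatter) in this assay. Compound 4 is estimated at 32000 nM, between 12000 nM and 100000 nM.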

Compound 4, half-maximal inhibitory concentration: 66700 nM
Beside the measured number, compound 4's estimate is 2.1-fold (0.32 log units) below it, and the stated range covers the measured number.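

In this assay, chloro in place of fluoro on the core of compound 1 gives a 2.3-fold higher number from compound 1 to compound 4 (0.37 log units; beyond the scatter), so on this core the 2-chlorobenzyl compound is the weaker inhibitor. On the core of compound 3 the same change leads to compound 2, but both ends of that step are limits of the assay and not numbers, so its size cannot be read. The step therefore stands on one pair alone, and it does not show whether the change carries from one core to the other with the same direction or size.

The compounds shown leave open how a bromo or a methyl in the same place on the aromatic ring would read. They also leave open how an amine or a carboxylic acid there would read.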